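This account rests on a few compounds, and the source may have more. Where it says the series, first, only, none or still open, it means among the compounds named here.

Values in a functional assay on MDA-MB-231 cells (Homo sapiens) for antiproliferative activity, read by sulforhodamine B assay; on this read-out higher numbers stand for weaker inhibition of growth and lower numbers for stronger inhibition of growth:
- Compound 1 `COc1cccc(OCCC(C)(C)C)c1C(=O)/C=C/c1ccc(O)cc1`: > 30000 nM (a limit)
- Compound 2 `CCCCCCOc1cccc(O)c1C(=O)/C=C/c1ccc(O)cc1`: > 30000 nM (a limit)
- Compound 3 `CC(C)(C)CCOc1cccc(O)c1C(=O)/C=C/c1ccc(O)cc1`: 2380 nM

Compound 2 gives > 30000 nM, which is a limit and not a number. Compound 2 therefore stands at the limit of > 30000 nM in this assay, at which 2 of the 3 values shown sit, so any step starting from it has an open end.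

The unmeasured compound 4 `O=C(/C=C/c1ccc(O)cc1)c1c(O)cccc1OCC1CCCCC1` differs from compound 2 by cyclohexyl in place of pentyl on a saturated chain carbon bound to an oxygen on an aromatic ring.

The closest measured change is an at least 12-fold lower number from compound 2 to compound 3 (1.10 log units; beyond the scatter), a large step beyond the scatter, with tert-butyl in place of butyl in the same chain. Going by the values given here, it is the only measured change to this chain, and a ring at the chain end has not yet been tested. The other measured step, an at least 12-fold lower number from compound 1 to compound 3 (1.10 log units; beyond the scatter), is also large, but it concerns the hydrogen in place of methyl on an oxygen on an aromatic ring, and compound 4 keeps that hydrogen.

A move towards stronger inhibition of growth is therefore expected, probably not the full size of the step to compound 3, and a second limit remains possible. The expected change is an at least 5.0-fold lower number from compound 2 to compound 4 (0.69 log units; beyond the scatter). For compound 4 the estimated value is 6000 nM, with an expected range from 1500 nM to 30000 nM.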

Compound 4, concentration for 50% growth inhibition: > 30000 nM
Compound 4: only a limit was reported; the forecaster's own chance of this, stated with the estimate: 35%; at least 5.0-fold (0.69 log units) between middle value and limit.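

In this assay, moving from the neopentyl group to a cyclohexyl group on this chain gives an at least 12-fold higher number from compound 3 to compound 4 (1.10 log units; beyond the scatter), so the result at compound 3 does not carry over to this ring-bearing chain. The value of compound 4 is a limit, and the step from compound 2 to compound 4 cannot be read, which leaves the hexyloxy and cyclohexylmethoxy chains unranked against each other. Among the three compounds that keep the hydrogen on the other oxygen, only compound 3 gives a number, while compounds 2 and 4 go against any reading that a chain of this general size is enough, and the series now sits largely at one edge of the assay: the limit of > 30000 nM in this assay, at which 3 of the 4 values shown sit.

Open, going by these compounds, is whether the number for compound 3 depends on the tert-butyl end itself or on the length of chain that carries it, a question that a cyclohexylethoxy chain or a shorter chain ending in tert-butyl would help to separate. Also open, on these data alone, is how an amine or a carboxylic acid at the chain end would read in this assay.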